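Changing one stereocentre on the aminopiperidine amide

The source may report more compounds than this note shows. Statements on the series, on what has been measured and on what is new or still open speak of the compounds shown alone.

- Compound 1 `O=C(c1ccc(-c2ccc3ncc(-c4ccc5cnccc5c4)n3c2)cc1)N1CCC(N2CCCCC2)CC1`: 4010 nM
- Compound 2 `N[C@H]1CCCN(C(=O)c2ccc(-c3ccc4ncc(-c5ccc6cnccc6c5)n4c3)cc2)C1`: 3470 nM

Among the compounds with values here, in a functional assay on TMD8 cells (Homo sapiens) for antiproliferative activity, read by MTT assay, with a stated time of 72 h (a lower number here means a stronger inhibitor, a higher number a weaker inhibitor), only two compounds have numbers so far. Compound 2 gives 3470 nM, which lies within the usual scatter of compound 1 at 4010 nM, so the two stand level.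

The next compound is compound 3 `N[C@@H]1CCCN(C(=O)c2ccc(-c3ccc4ncc(-c5ccc6cnccc6c5)n4c3)cc2)C1`. Its difference from compound 2 is small: the two compounds have the same atoms and bonds and differ only in configuration as drawn: 1 of 1 stereo elements differ; a stereocentre at a saturated ring carbon is drawn S in compound 2 and R in compound 3. The atoms and bonds stay the same, and only the configuration as drawn changes.

Within the data shown here, the one measured step is a 1.2-fold lower number from compound 1 to compound 2 (0.06 log units; within the scatter). It puts 3-aminopiperidin-1-yl in place of 4-(piperidin-1-yl)piperidin-1-yl on a carbonyl carbon and stays within the scatter. That step changes a group, not a configuration, so it offers only indirect guidance. Among the measured compounds shown here, no measured pair yet shows what a change at this stereocentre does, and a larger shift cannot be ruled out.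

The estimated step is a 1.0-fold higher number from compound 2 to compound 3 (0.00 log units; within the scatter), meaning no change beyond the scatter is expected. Compound 3 is expected at about 3500 nM, with an estimated range of 1400 nM to 8000 nM.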

Compound 3, half-maximal inhibitory concentration: 2300 nM
Estimate against measurement, compound 3: 1.5-fold (0.18 log units) above, and the stated range covers the measured number.
By their numbers in this assay, from the lowest: compounds 3, 2 and 1 (each within the scatter of the next).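

In this assay, redrawing the saturated ring carbon from S to R gives a 1.5-fold lower number from compound 2 to compound 3 (0.18 log units; within the scatter), so the first direct test of this stereocentre does not separate the two forms. Exchanging the group on the carbonyl carbon, with 3-aminopiperidin-1-yl in place of 4-(piperidin-1-yl)piperidin-1-yl, gives a 1.7-fold lower number from compound 1 to compound 3 (0.24 log units; within the scatter), so the R form, like the S form, stands level with compound 1. Compounds 2 and 3 are the cleanest comparison in this small set, as only one feature can account for any gap between them: the fact that compounds 2 and 3 differ only in the configuration as drawn

The compounds shown leave open whether anything on this amide can move the number beyond the scatter, for example a carboxylic acid in place of the ring amino group, or an open-chain amine on a longer chain in place of the piperidine ring. They also leave open whether the stereocentre would matter once the amino group is moved to another ring carbon or carries a methyl group.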